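Ethyl in Place of Hydrogen on the Amide-Type Nitrogen

The source may report more compounds than this note shows. Statements on the series, on what has been measured and on what is new or still open speak of the compounds shown alone.

Within the data shown here, compound 3 `N#CC1CN1C(N)=O` stands only as a boundary in the numbers so far. In a functional assay on A549 cells (Homo sapiens) for inhibition (a lower number here means a stronger inhibitor, a higher number a weaker inhibitor), compound 3 gives > 280000 nM, which is a limit of the assay rather than a measured number. Compound 1 `CCCCNC(=O)N1CC1C#N` gives 18000 nM in this assay, and compound 2 `CC(C)(C)NC(=O)N1CC1C#N` gives 180000 nM. Compound 4 `CCNC(=O)N1CC1C#N` differs from compound 3 by ethyl in place of hydrogen on an amide-type nitrogen. The relevant comparisons are an at least 15-fold higher number from compound 1 to compound 3 (1.19 log units; beyond the scatter) and the smaller at least 1.5-fold higher number from compound 2 to compound 3 (0.19 log units; that floor lies within the scatter), both bounded by the limit of > 280000 nM in this assay, at which 1 of the 3 values shown sits. Ethyl sits between hydrogen and butyl in chain length, so a number below the limit is expected for compound 4, an at least 4.6-fold lower number from compound 3 to compound 4 (0.66 log units; beyond the scatter). Compound 4 is estimated at 60000 nM, with a range from 20000 nM to 250000 nM.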

Compound 4, half-maximal inhibitory concentration: 18000 nM
Compound 4: middle estimate off by 3.3-fold (0.52 log units), on the high side; the whole stated range lies above it.
By their numbers in this assay, from the lowest: compounds 1 and 4 (each within the scatter of the next); then compound 2. At a limit, above all of these: compound 3.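

Ethyl on the amide-type nitrogen is enough to leave the limit, an at least 15-fold lower number from compound 3 to compound 4 (1.19 log units; beyond the scatter) in this assay, and butyl reads no differently, no change at the digits printed from compound 1 to compound 4 (within the scatter). The branched tert-butyl is the one that stands apart from ethyl, a 10-fold lower number from compound 2 to compound 4 (1.00 log units; beyond the scatter). Compound 3 stands at a limit of the assay, so the step from hydrogen is only a floor: the limit of > 280000 nM in this assay, at which 1 of the 4 values shown sits.

Left open is how methyl, propyl or a chain longer than butyl would read on this nitrogen. Also open, as far as these compounds go, is whether an amine or a carboxylic acid at the end of the chain would keep this level.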